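Dropping one methoxy from a bis-methoxyphenyl triazole

This account rests on a few compounds, and the source may have more. Where it says the series, first, only, none or still open, it means among the compounds named here.

Measured so far:
compound 1 `COc1ccc(OC)c(-c2cn(-c3ccc(O)c(C(=O)Nc4cccc(C(F)(F)F)c4)c3)nn2)c1`, 15%
compound 2 `COC(=O)c1cc(-n2cc(-c3cc(O)ccc3O)nn2)ccc1O`, 52%

In a functional assay on CCRF-CEM cells (Homo sapiens) for inhibition, read by MTT assay, with a stated time of 2 days, tested at 10 uM (on this read-out lower numbers stand for less inhibition and higher numbers for more inhibition at the one concentration tested (going by the name of the read-out)), compound 1 gives 15%, the lowest of the two numbers shown, and the gap to compound 2 lies beyond the scatter. Compound 3 `COc1ccccc1-c1cn(-c2ccc(O)c(C(=O)Nc3cccc(C(F)(F)F)c3)c2)nn1` differs from compound 1 by hydrogen in place of methoxy on an aromatic carbon, the change reading as 2,5-dimethoxyphenyl to 2-methoxyphenyl. Among the compounds with values here, no measured pair shows such a step, so the size of the step is unknown; a step within the scatter, or none at all, is expected. Compound 3 is therefore expected to give about 15%, from 0% to 35%, meaning an expected step of no change at the digits printed from compound 1 to compound 3 (within the scatter).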

Compound 3, a percentage reported as inhibition, at one concentration (the size of the read-out at that concentration, not a potency): 65%
Beside the measured number, compound 3's estimate is 50 percentage points below it; the whole stated range lies below it.
By their numbers in this assay, from the lowest: compound 1; then compound 2; then compound 3.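

In this assay the change from 2,5-dimethoxyphenyl to 2-methoxyphenyl gives a number 50 percentage points higher from compound 1 to compound 3 (beyond the scatter) and so shows that this ring carbon, meta to a large group and para to a methoxy group, is far from indifferent to what it carries. No measurement available here bears on the cause of this step. The compounds shown leave open whether a fluorine, an amine or a carboxylic acid on this carbon would keep the inhibition, and whether the remaining methoxy group is needed at all.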